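Replacing the 5-chlorofuran-2-yl group of compound 3

The compounds below may be only part of what the source reports. "The series", "measured", "known", "first", "only" and "open" are said of these compounds alone.

Measured in a functional assay on HeLa cells (Homo sapiens) for cytotoxicity, in the presence of a further agent that is not named here; on this read-out higher numbers stand for weaker inhibition and lower numbers for stronger inhibition:
Compound 1 `Clc1ccc(-c2cc(-c3ccsc3)nc(-c3ccco3)c2)o1`: > 50000 nM (a limit)
Compound 2 `Cc1ccccc1-c1cc(-c2ccc(Cl)o2)cc(-c2ccsc2)n1`: 9770 nM
Compound 3 `Clc1ccc(-c2cc(-c3ccc(Cl)o3)cc(-c3ccsc3)n2)cc1`: 8410 nM

Compound 3 has just one neighbour with a true number, and a 1.2-fold lower number from compound 2 to compound 3 (0.07 log units; within the scatter) stays within the scatter. Compound 4 `Clc1ccc(-c2cc(-c3ccoc3)cc(-c3ccsc3)n2)cc1` carries furan-3-yl in place of 5-chlorofuran-2-yl on an aromatic carbon. Going by the values given here, no measured step changes this group, so the evidence is indirect. At another place on the core, an at least 5.1-fold lower number from compound 1 to compound 2 (0.70 log units; beyond the scatter) and an at least 5.9-fold lower number from compound 1 to compound 3 (0.77 log units; beyond the scatter) each remove an unsubstituted furan-2-yl group, showing that one ring swap can matter. Compound 4 gains an unsubstituted furan, so a modest move towards weaker inhibition seems likely. The expected change is a 1.9-fold higher number from compound 3 to compound 4 (0.28 log units; within the scatter). Compound 4 is estimated at 16000 nM, with an expected range of 5000 nM to 50000 nM.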

Compound 4, half-maximal inhibitory concentration: 4140 nM
The estimate for compound 4 lay 3.9-fold (0.59 log units) above the measured number, outside the stated range (below it).
By their numbers in this assay, from the lowest: compound 4; then compounds 3 and 2 (each within the scatter of the next). At a limit, above all of these: compound 1.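

Going by these compounds alone, this is the first measured change at the position opposite the ring nitrogen, and in this assay it gives a 2.0-fold lower number from compound 3 to compound 4 (0.31 log units; beyond the scatter). The 5-chlorofuran-2-yl group is therefore not required for a measurable number here, and a furan-3-yl group without chlorine moves the read-out modestly towards stronger inhibition. Nothing given here explains this shift.

The swap removes the chlorine and also moves the furan's point of attachment, and which of the two accounts for the step stays open. Equally open, going by these compounds, is how an amine or a carboxylic acid at this position would read.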